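A Methoxy Group Added to Compound 3

A few compounds are considered here, and "the series" means these few. Any claim that something is new, unique, unknown or untested is made for them only; others in the source may bear on it.

- compound 1 `COc1ccc(-c2nc3sc(-c4ccccc4)cn3n2)cc1`: 81%
- compound 2 `COc1cc(-c2nc3sc(-c4ccccc4)cn3n2)cc(OC)c1OC`: 35%
- compound 3 `Clc1ccc(-c2cn3nc(-c4ccccc4)nc3s2)cc1`: 57%

All three values come from a functional assay on MDA-MB-468 cells (Homo sapiens) for inhibition, read by sulforhodamine B assay, with a stated time of 48 h, tested at 10 uM; on this read-out higher numbers stand for more inhibition of growth at the one concentration tested and lower numbers for less inhibition of growth. Compound 3 holds the middle place, and its gaps to the other two lie beyond the usual scatter of this kind of measurement. At 57%, compound 3 sits clearly above compound 2 and clearly below compound 1.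

The next compound to be tested is compound 4 `COc1ccc(-c2nc3sc(-c4ccc(Cl)cc4)cn3n2)cc1`. It differs from compound 3 by a methoxy in place of hydrogen on an aromatic carbon, on a six-membered aromatic ring of carbon only, para to a large group (methoxy in place of hydrogen on an aromatic carbon).

Among the compounds with values here, no pair of tested compounds differs in one place only, so no measured step serves as a direct guide. Compound 1 carries the same methoxy-bearing ring as compound 4, which points upward. Compound 2 goes against any simple rule about methoxy groups, since it also carries them and gives only 35%.

A moderate rise is expected because compound 1 gives 81%. The expected change is a number 13 percentage points higher from compound 3 to compound 4 (beyond the scatter), a step estimated to lie slightly beyond the scatter.

The estimate for compound 4 is 70%, with an expected range from 50% to 88%.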

Compound 4, percent growth inhibition at one concentration: 66.6%
The estimate for compound 4 lay 3.4 percentage points above the measured number; measured number inside the range.
By their numbers in this assay, from the lowest: compound 2; then compounds 3 and 4 (each within the scatter of the next); then compound 1.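

In this assay, within the data shown here, these are the first comparisons between compounds that differ in one place only. Putting methoxy in place of hydrogen on an aromatic carbon of a six-membered aromatic ring of carbon only, para to a large group, gives a number 9.6 percentage points higher from compound 3 to compound 4 (within the scatter), so the position accepts this change, but the step cannot be counted as a real gain. Chloro in place of hydrogen on an aromatic carbon gives a number 14.4 percentage points lower from compound 1 to compound 4 (beyond the scatter), and this modest fall is the only one of the two steps that stands clear of ordinary measurement noise.

No supporting measurement is available to explain the size of either step. Still open, on these data alone, is whether an amine, a carboxylic acid or a longer chain such as ethoxy at the methoxy position would move the number clearly away from that of compound 3, and whether the fall seen with chloro would recur on compounds outside this pair.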